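The source may hold more compounds than are shown below. What is called first, only, known or untested is meant among the compounds shown, and "the series" means these compounds.

Working notes on the series. Compound 1 `CCOc1cccc(C(CC)c2ccc(O)c(OC)c2)c1O` and compound 2 `CCC(c1ccc(O)c(OC)c1)c1ccccc1O` carry the shared core. In a functional assay for inhibition, with a stated time of 36 h, tested at 100 ug/mL (a lower number here means less inhibition, a higher number more inhibition at the concentration tested (going by the name of the read-out)), compound 1 gives 96%, and in this assay compound 2 gives 96%. Among the compounds with values here, the single measured step, no change at the digits printed from compound 1 to compound 2 (within the scatter), is the only guide to how this series responds to change on an aromatic carbon. Compound 2 therefore stands level with compound 1 at the digits shown, close to the top of the read-out scale.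

The next compound, compound 3 `CCC(c1ccc(O)c(OC)c1)c1ccc(O)cc1O`, differs from compound 2 in one place: hydroxy in place of hydrogen on an aromatic carbon. Within the data shown here, no measured step introduces a hydroxy group, so the step of no change at the digits printed from compound 1 to compound 2 (within the scatter) bears on it only indirectly; it shows that one change on an aromatic carbon left the read-out within its scatter. Because compound 2 already gives 96%, little room remains upward, and a step beyond the scatter in this assay is expected in neither direction, so the step of a number 2 percentage points lower from compound 2 to compound 3 (within the scatter) is the expected outcome. Compound 3 is estimated to give 94%, within a range from 80% to 100%.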

Compound 3, a percentage reported as inhibition, at one concentration (the size of the read-out at that concentration, not a potency): 94%
The estimate for compound 3 equals the measured number at the digits printed; measured number inside the range.
By their numbers in this assay, from the lowest: compounds 3, 1 and 2 (each within the scatter of the next).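

With a hydroxy group in place of hydrogen on an aromatic carbon of a six-membered aromatic ring of carbon only, meta to a hydroxy group and para to a large group, this assay gives a number 2 percentage points lower from compound 2 to compound 3 (within the scatter). Within the data shown here, the earlier step concerned ethoxy on another aromatic carbon, so this is the first sign that this position accepts a hydroxy group with the read-out staying within the scatter, and the series now has two single-place changes on aromatic carbons that leave the read-out level. At a single concentration, this shows that the number stays level with the added hydroxy group but gives no measure of potency, and no supporting data bear on why the read-out holds at this position.

The compounds shown leave open whether an amine, a carboxylic acid or a longer alkoxy chain on this same aromatic carbon would keep the read-out at this level. They also leave open whether compounds that are level at this one concentration would remain level at lower concentrations, where the read-out would have more room to separate them.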